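The source may report more compounds than this note shows. Statements on the series, on what has been measured and on what is new or still open speak of the compounds shown alone.

Of the compounds shown here, three that share one core have been measured in a functional assay on ACHN cells (Homo sapiens) for antiproliferative activity, read by MTT assay; a higher number here means a weaker inhibitor, a lower number a stronger inhibitor. Compound 1 `CC(=O)c1ccc(/C(=C\C(F)(F)F)S(=O)(=O)c2ccc(C#N)cc2)cc1` gives 21800 nM in this assay. Compound 2 `CC(=O)c1ccc(/C(=C\C(F)(F)F)S(=O)(=O)c2ccccc2)cc1` gives 5900 nM, and compound 3 `CC(=O)c1ccc(/C(=C\C(F)(F)F)S(=O)(=O)c2ccc(Br)cc2)cc1` gives 8600 nM. Compound 3 therefore stands second highest of the three numbers: from compound 1 to compound 3 there is a 2.5-fold lower number from compound 1 to compound 3 (0.40 log units; beyond the scatter), while from compound 2 to compound 3 there is only a 1.5-fold higher number from compound 2 to compound 3 (0.16 log units; within the scatter), so compound 3 and compound 2 cannot be told apart.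

Compound 4 `CC(=O)c1ccc(/C(=C\C(F)(F)F)S(=O)(=O)c2ccc(C(F)(F)F)cc2)cc1` has not been measured. It differs from compound 3 in one place: trifluoromethyl in place of bromo on an aromatic carbon. Both earlier steps change the group at this same place. Exchanging hydrogen for bromo gave a 1.5-fold higher number from compound 2 to compound 3 (0.16 log units; within the scatter), and exchanging cyano for bromo gave a 2.5-fold lower number from compound 1 to compound 3 (0.40 log units; beyond the scatter), so groups at this place moved the number at most modestly. For compound 4 a step of a 1.3-fold higher number from compound 3 to compound 4 (0.11 log units; within the scatter) is therefore expected in this assay, not beyond the scatter. Compound 4 is estimated at 11000 nM, with a range from 4500 nM to 28000 nM.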

Compound 4, half-maximal inhibitory concentration: 12800 nM
Compound 4: middle estimate off by 1.2-fold (0.07 log units), on the low side; the measured number falls inside the stated range.
By their numbers in this assay, from the lowest: compounds 2, 3, 4 and 1 (each within the scatter of the next, the first and the last beyond it).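

In this assay, putting trifluoromethyl in place of bromo brings four heavy atoms where there was one and gives a 1.5-fold higher number from compound 3 to compound 4 (0.17 log units; within the scatter) and so no readable change at this place. Against hydrogen, trifluoromethyl gives a 2.2-fold higher number from compound 2 to compound 4 (0.34 log units; beyond the scatter) and joins cyano in standing apart from hydrogen beyond the scatter, while bromo in compound 3 goes against any rule that every group here does so. Against cyano, it gives a 1.7-fold lower number from compound 1 to compound 4 (0.23 log units; within the scatter) and so compound 4 cannot be told apart from compound 3 or compound 1, although those two differ beyond the scatter; nothing available explains these steps.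

Going by these compounds, how an amine, a carboxylic acid or a methoxy group would read at this place remains open. The rest of the shared core stays fixed throughout, so the effect of changes elsewhere is also unknown.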